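Carbonyl-side aryl swap in a two-compound series

The compounds below may be only part of what the source reports. "The series", "measured", "known", "first", "only" and "open" are said of these compounds alone.

Two compounds of the shared core have numbers in a functional assay on KM12 cells (Homo sapiens) for inhibition, read by sulforhodamine B assay, with a stated time of 48 h; on this read-out higher numbers stand for weaker inhibition of growth and lower numbers for stronger inhibition of growth. Compound 1 `COc1ccc(-c2cc(/C=C/C(=O)c3ccc(N)cc3)[nH]n2)cc1` gives 1540 nM. Compound 2 `COc1cc(-c2cc(/C=C/C(=O)c3ccc(Cl)c(Cl)c3)[nH]n2)cc(OC)c1OC` gives 3370 nM, the higher of the two; its gap to compound 1 is beyond the scatter. Compound 3 `COc1ccc(C(=O)/C=C/c2cc(-c3cc(OC)c(OC)c(OC)c3)n[nH]2)cc1` differs from compound 2 by 4-methoxyphenyl in place of 3,4-dichlorophenyl on a carbonyl carbon. For the measured compounds named here, no measured pair shows this change, so in this assay the step from compound 2 to compound 3 is expected to be small, at most a modest move toward a lower number, and not clearly beyond the scatter. Compound 3 is estimated at 2500 nM, within 800 nM to 8000 nM. The expected step is a 1.3-fold lower number from compound 2 to compound 3 (0.13 log units; within the scatter).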

Compound 3, concentration for 50% growth inhibition: 1560 nM
The estimate for compound 3 lay 1.6-fold (0.20 log units) above the measured number; low and high end bracket the measured number.
By their numbers in this assay, from the lowest: compounds 1 and 3 (each within the scatter of the next); then compound 2.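

For the compounds shown here, on a carbonyl carbon, 4-methoxyphenyl in place of 3,4-dichlorophenyl gives the first readable single-place step in this assay, a 2.2-fold lower number from compound 2 to compound 3 (0.33 log units; beyond the scatter), a modest step. Going by these compounds alone, this position therefore responds to a change of its aryl group, although one pair gives only one step and no trend. Nothing measured here accounts for the step. Going by these compounds, it remains open whether an unsubstituted phenyl, a single chlorine or a carboxylic acid on this ring would move the number further. On these data alone, whether the step carries over to the core of compound 1 also remains open.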